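The source may report more compounds than this note shows. Statements on the series, on what has been measured and on what is new or still open speak of the compounds shown alone.

Working notes on the series. All three measured compounds carry the same core and the same three-carbon diamine linker, differing in the group on the core and in the benzyl-type end of the chain. Compound 1 `c1ccc(-c2ccc3c(NCCCNCc4ccco4)ccnc3c2)cc1` gives 9.47 in a physicochemical assay for acid dissociation. Compound 2 `COc1cccc(CNCCCNc2ccnc3cc(Oc4ccc(Cl)cc4)ccc23)c1O` gives 9.28 in this assay, and compound 3 `COc1ccc(F)cc1CNCCCNc1ccnc2cc(CCC(C)C)ccc12` gives 9.47. Compound 2 sits together with compound 1 and compound 3 inside a single band: the differences among the three do not exceed the usual scatter, so no ranking among them can be drawn from these numbers.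

Compound 4 `COc1cccc(CNCCCNc2ccnc3cc(-c4ccc(C(F)(F)F)cc4)ccc23)c1O` has not yet been measured. Relative to compound 2 the change is 4-(trifluoromethyl)phenyl in place of 4-chlorophenoxy on an aromatic carbon. Among the compounds with values here, no step between measured compounds covers this change. Across compound 1, compound 2 and compound 3 the substituent on the core already varies widely while the readings stay within the scatter of one another, so the step of a number 0.07 log units higher from compound 2 to compound 4 (within the scatter) is expected to stay within the scatter as well. Compound 4 is therefore estimated at 9.35, within a range from 9 to 9.7.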

Compound 4, acid dissociation constant: 9.47
Compound 4: the middle estimate sits 0.12 log units below what was measured; the range from low to high includes it.
By their numbers in this assay, from the lowest: compounds 2, 1, 3 and 4 (each within the scatter of the next).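

Within the data shown here, the step of a number 0.19 log units higher from compound 2 to compound 4 (within the scatter) in this assay is the first reading of a change at this aromatic carbon with the rest of the structure held constant. The earlier compounds shown here differ both in the group on the core and in the benzyl-type end of the chain, whereas this pair shows that 4-(trifluoromethyl)phenyl in place of 4-chlorophenoxy alone leaves the reading within the scatter. No measurement at hand bears on the reason for this result.

The compounds shown leave open whether an amine or a carboxylic acid on this aromatic carbon would also stay within the scatter of compound 2. They also leave open how a longer chain in the diamine linker would read in this assay with the group on the core held constant.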